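Removing a Methyl from an Aryl Ether in Urea Pyrazoles

This account rests on a few compounds, and the source may have more. Where it says the series, first, only, none or still open, it means among the compounds named here.

Compound 1, `O=C(Nc1cccc(-n2cc(-c3ccncc3)c(-c3ccc(Cl)c(O)c3)n2)c1)Nc1cccc(C(F)(F)F)c1`: > 32500 nM in a functional assay on NCI-H460 cells (Homo sapiens) for inhibition, read by sulforhodamine B assay, with a stated time of 48 h (a lower number here means that less compound is tolerated, a higher number that more compound is tolerated), a limit rather than a number.
Compound 2, `COc1cc(-c2nn(-c3cccc(NC(=O)Nc4ccc(Cl)c(C(F)(F)F)c4)c3)cc2-c2ccncc2)ccc1Cl`: > 32500 nM in this assay, again only a limit.

Compound 2 therefore stands at the edge of what this assay reports, with no number of its own: the limit of > 32500 nM in this assay, at which 2 of the 2 values shown sit. Nothing measured separates it from compound 1, since both readings are limits.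

Compound 3, `O=C(Nc1cccc(-n2cc(-c3ccncc3)c(-c3ccc(Cl)c(O)c3)n2)c1)Nc1ccc(Cl)c(C(F)(F)F)c1`, differs from compound 2 by hydrogen in place of methyl on an oxygen on an aromatic ring. Going by the values given here, no measured step covers this change. Compound 1 also carries the hydroxy group, and its reading is a limit as well. The step from compound 2 to compound 3 is expected to be none beyond the scatter, a step that the limit leaves unreadable from compound 2 to compound 3, with the result most likely again a limit. Compound 3 is expected to give about 50000 nM, within 20000 nM to 150000 nM.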

Compound 3, concentration lethal to 50% of the cells: > 32500 nM
Compound 3 ended at the assay's limit; the forecaster's own chance of this, stated with the estimate: 85%; the middle value does not contradict the limit.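

Compound 1, compound 2 and compound 3 all end at the same reported limit, so no step between compound 3 and either of the others can be read: the limit of > 32500 nM in this assay, at which 3 of the 3 values shown sit.

What the compounds shown leave open is how methoxy and hydroxy, or chloro and hydrogen, compare in this assay, since none of the three gives a number of its own.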